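Adding a Methyl Beside Chloro on the Aryl Urea

This account rests on a few compounds, and the source may have more. Where it says the series, first, only, none or still open, it means among the compounds named here.

Two ureas sharing one core have been tested in a functional assay on PC-3 cells (Homo sapiens) for antiproliferative activity, read by MTT assay, with a stated time of 48 h; a higher number here means a weaker inhibitor, a lower number a stronger inhibitor. Compound 1 `O=C(Nc1cccc(Cl)c1)Nc1nnc(Sc2ncnc3scc(-c4ccncc4)c23)s1` gives 8000 nM. Compound 2 `O=C(Nc1cccc(C(F)(F)F)c1)Nc1nnc(Sc2ncnc3scc(-c4ccncc4)c23)s1`, which carries trifluoromethyl in place of chloro on an aromatic carbon, gives 11500 nM. Of the two numbers, compound 2 stands at the upper one, with the step of a 1.4-fold higher number from compound 1 to compound 2 (0.16 log units; within the scatter) separating it from compound 1.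

Compound 3 `Cc1ccc(NC(=O)Nc2nnc(Sc3ncnc4scc(-c5ccncc5)c34)s2)cc1Cl` has not yet been measured. It differs from compound 2 by 3-chloro-4-methylphenyl in place of 3-(trifluoromethyl)phenyl on an amide-type nitrogen. Among the measured compounds shown here, the only measured step that bears on this change is a 1.4-fold higher number from compound 1 to compound 2 (0.16 log units; within the scatter), since compound 3 brings back the chloro of compound 1 and adds a methyl. Because a 1.4-fold higher number from compound 1 to compound 2 (0.16 log units; within the scatter) is within the scatter, no shift beyond the scatter is expected in this assay. Compound 3 is therefore estimated at 8500 nM, within a range from 3000 nM to 25000 nM. The step of a 1.4-fold lower number from compound 2 to compound 3 (0.13 log units; within the scatter) is thus expected to stay within the scatter.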

Compound 3, half-maximal inhibitory concentration: 4700 nM
The estimate for compound 3 lay 1.8-fold (0.26 log units) above the measured number; measured number inside the range.
By their numbers in this assay, from the lowest: compounds 3, 1 and 2 (each within the scatter of the next, the first and the last beyond it).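

In this assay the group on the amide-type nitrogen now shows a step beyond the scatter, though only a modest one: swapping 3-(trifluoromethyl)phenyl for 3-chloro-4-methylphenyl gives a 2.4-fold lower number from compound 2 to compound 3 (0.39 log units; beyond the scatter). Taken alone, methyl in place of hydrogen on an aromatic carbon gives a 1.7-fold lower number from compound 1 to compound 3 (0.23 log units; within the scatter), so the effect of that single change cannot be told apart from the repeat scatter. Nothing measured here explains why the full swap shifts the number.

Going by these compounds, whether a longer chain such as ethyl in place of the methyl, or an amine or methoxy in place of the chloro, would shift the number further remains open. The shared core is the same in all three compounds, so they also leave open how any change to it would read in this assay.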